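Azido nucleosides: from compound 2 to its demethylated analogue

The source may report more compounds than this note shows. Statements on the series, on what has been measured and on what is new or still open speak of the compounds shown alone.

Measured so far:
compound 1, `C=CCN(C)c1nc(N)nc2c1ncn2[C@H]1C[C@H](N=[N+]=[N-])[C@@H](CO)O1` — 27000 nM
compound 2, `CNc1nc(Cl)nc2c1ncn2[C@H]1C[C@H](N=[N+]=[N-])[C@@H](CO)O1` — > 100000 nM
compound 3, `C=CCNc1ncnc2c1ncn2[C@H]1C[C@H](N=[N+]=[N-])[C@@H](CO)O1` — > 100000 nM

In an ADME assay on CCRF-CEM cells (Homo sapiens) for cytotoxicity, with a stated time of 5 days (a higher number here means a weaker inhibitor, a lower number a stronger inhibitor), compound 1 gives 27000 nM. For compound 2 the assay reports only a limit, > 100000 nM. For compound 3 likewise only a limit is reported, > 100000 nM. Compound 2 thus sits at the limit of > 100000 nM in this assay, at which 2 of the 3 values shown sit, and stands at the weak end of what has been measured, with no number to build on.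

Compound 4, `[N-]=[N+]=N[C@H]1C[C@H](n2cnc3c(N)nc(Cl)nc32)O[C@@H]1CO`, differs from compound 2 by one change: hydrogen in place of methyl on a nitrogen on an aromatic ring. Methyl leaves, hydrogen enters, on the nitrogen on an aromatic ring; cut one bond further out, methylamino becomes amino.

Among the compounds with values here, with no measured step to guide the size, the expectation for compound 4 is a move toward stronger inhibition in this assay, of an at least 1.6-fold lower number from compound 2 to compound 4 (0.22 log units; that floor lies within the scatter), but with wide uncertainty. Compound 4 is estimated at 60000 nM, between 15000 nM and 250000 nM.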

Compound 4, half-maximal inhibitory concentration: > 100000 nM
Compound 4 was reported as a limit; the forecaster's own chance of this, stated with the estimate: 45%; middle value at least 1.6-fold (0.22 log units) away from the limit.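

Compound 2 and compound 4 are both reported only as limits, so no step can be read between them: the limit of > 100000 nM in this assay, at which 3 of the 4 values shown sit.

The compounds shown leave open whether hydrogen in place of methyl on a nitrogen on an aromatic ring changes the result at all.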